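Chloro for methoxy on the N-aryl of compound 3

The source may report more compounds than this note shows. Statements on the series, on what has been measured and on what is new or still open speak of the compounds shown alone.

Compound 1 `Cn1c(=O)c(C(=O)Nc2ccc(Oc3ccncc3-c3cccnc3)c(F)c2)nn(-c2ccccc2F)c1=O` and compound 2 `COc1ccc(-n2nc(C(=O)Nc3ccc(Oc4ccncc4-c4cccnc4)c(F)c3)c(=O)n(C)c2=O)c(OC)c1` share one core and differ only on the aromatic nitrogen. In a functional assay on HT-29 cells (Homo sapiens) for cytotoxicity, read by MTT assay, with a stated time of 72 h (a lower number here means a stronger inhibitor, a higher number a weaker inhibitor), compound 1 gives 2100 nM, and compound 2 gives 890 nM. Among the compounds with values here, the single measured step, a 2.4-fold lower number from compound 1 to compound 2 (0.37 log units; beyond the scatter), shows that the group on that nitrogen moves the number, though only modestly. Compound 3 `COc1ccc(-n2nc(C(=O)Nc3ccc(Oc4ccncc4-c4cccnc4)c(F)c3)c3ccccc3c2=O)cc1` carries a different core, and in this assay compound 3 gives "not determined" (no result reported), so it stands nowhere on the numbers shown and offers no anchor. Compound 4 `O=C(Nc1ccc(Oc2ccncc2-c2cccnc2)c(F)c1)c1nn(-c2ccc(Cl)cc2)c(=O)c2ccccc12` differs from compound 3 by chloro in place of methoxy on an aromatic carbon. Within the data shown here, the step from compound 1 to compound 2 is the only one touching the same region, and it runs from a halogen on that phenyl to methoxy groups, so the reverse exchange here would be expected, if anything, to raise the number by a modest amount, at the edge of the scatter; the core is different and no measured step on it exists. Compound 4 is therefore estimated at 1500 nM, with a range from 350 nM to 6500 nM, wide for want of a value for compound 3.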

Compound 4, half-maximal inhibitory concentration: 710 nM
For compound 4 the middle estimate is 2.1-fold (0.32 log units) above the measured one; low and high end bracket the measured number.
By their numbers in this assay, from the lowest: compounds 4 and 2 (each within the scatter of the next); then compound 1.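

In this assay, within the data shown here, compound 3 has no single number, so no step to compound 4 at 710 nM can be read. The compounds shown leave open how the change from 4-methoxyphenyl to 4-chlorophenyl moves the number on this core. No further evidence bears on this result.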